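Trimming the benzyl quaternary ammonium to allyl

The source may report more compounds than this note shows. Statements on the series, on what has been measured and on what is new or still open speak of the compounds shown alone.

Compound 2 `COc1ccc(C(=O)COc2ccc([N+](C)(C)Cc3ccccc3)cc2)cc1OC` carries a benzyl group on the quaternary nitrogen. In a functional assay with Cavia porcellus as the target (on this read-out higher numbers stand for weaker inhibition and lower numbers for stronger inhibition), compound 2 gives 19400 nM, while compound 1 `COc1ccc(C(=O)COc2ccc([N+](C)(C)C)cc2)cc1OC` gives 9800 nM, and the shift a 2.0-fold higher number from compound 1 to compound 2 (0.30 log units; within the scatter) places the two side by side rather than apart. Compound 3 `C=CC[N+](C)(C)c1ccc(OCC(=O)c2ccc(OC)c(OC)c2)cc1` differs from compound 2 by vinyl in place of phenyl on a saturated chain carbon bound to a nitrogen on an aromatic ring. Among the measured compounds shown here, the only measured step touching this position is a 2.0-fold higher number from compound 1 to compound 2 (0.30 log units; within the scatter), so the data show no movement beyond the scatter for substituents here. Compound 3 is therefore expected to show a 1.4-fold lower number from compound 2 to compound 3 (0.14 log units; within the scatter), with an estimated 14000 nM spanning 5000 nM to 40000 nM.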

Compound 3, half-maximal inhibitory concentration: 500 nM
For compound 3 the middle estimate is 28-fold (1.45 log units) above the measured one; measured number outside the range, below it.
By their numbers in this assay, from the lowest: compound 3; then compounds 1 and 2 (each within the scatter of the next).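

In this assay this position proves sensitive after all: vinyl in place of phenyl gives a 39-fold lower number from compound 2 to compound 3 (1.59 log units; beyond the scatter), and vinyl in place of hydrogen gives a 20-fold lower number from compound 1 to compound 3 (1.29 log units; beyond the scatter). Hydrogen and phenyl, which lay within the scatter of each other, therefore did not show the range available here, and only the vinyl departs from them. Nothing at hand explains this departure.

The compounds shown leave open whether the double bond itself matters or a short chain would suffice, a question that a saturated propyl group in place of allyl would address.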